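Series notes: replacing the cyclopentyl acid arm of compound 1

A few compounds are considered here, and "the series" means these few. Any claim that something is new, unique, unknown or untested is made for them only; others in the source may bear on it.

Compound 1 `O=C(O)[C@@H](c1ccc(OCc2ccc3ccccc3n2)cc1)C1CCCC1` holds the second highest of the three numbers in hand in a functional assay for inhibition of Polyunsaturated fatty acid 5-lipoxygenase (Homo sapiens) (a higher number here means a weaker inhibitor, a lower number a stronger inhibitor), where compound 1 gives 60 nM. Compound 2 `O=C(O)/C(CSCCO)=N/OC(c1ccc(OCc2ccc3ccccc3n2)cc1)C1CCCCC1` gives 181 nM, a higher number beyond the scatter, while compound 3 `CC(C)(CC(O/N=C/C(=O)O)c1ccc(OCc2ccc3ccccc3n2)cc1)c1ccccc1` gives 10 nM, a lower number beyond the scatter. Compound 4 `C/C(=N\OCc1ccc(OCc2ccc3ccccc3n2)cc1)C(=O)O` differs from compound 1 in one place: a group of 8 heavy atoms (4 carbon, 1 nitrogen, 3 oxygen; no ring) in place of a group of 9 heavy atoms (7 carbon, 2 oxygen; one five-membered non-aromatic ring of carbon only), on an aromatic carbon The entering group sits on an aromatic carbon of a six-membered aromatic ring of carbon only, para to a large group. Among the compounds with values here, no pair of measured compounds tracks this change, so its size is untested here. The step of a 4.2-fold higher number from compound 1 to compound 4 (0.62 log units; beyond the scatter) is expected to run toward a higher number, beyond the scatter. Compound 4 is estimated at 250 nM, in a range from 60 nM to 1000 nM.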

Compound 4, half-maximal inhibitory concentration: 1400 nM
The estimate for compound 4 lay 5.6-fold (0.75 log units) below the measured number; measured number above the stated range.
By their numbers in this assay, from the lowest: compound 3; then compound 1; then compound 2; then compound 4.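

At this position, on an aromatic carbon para to a large group, the assay responds strongly to the arm carried: replacing carboxy(cyclopentyl)methyl with the ring-free group gives a 23-fold higher number from compound 1 to compound 4 (1.37 log units; beyond the scatter). The change removes the five-membered ring and the defined stereocentre and adds nitrogen and oxygen in a single step, so these parts cannot be separated. No measurement on hand explains the loss.

Open, from the compounds shown here alone, is which part of the change carries the step. An isopropyl in place of the cyclopentyl ring, with the rest of compound 1 unchanged, would address the ring alone.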